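Working notes on the shared core, toward compound 3

The source may hold more compounds than are shown below. What is called first, only, known or untested is meant among the compounds shown, and "the series" means these compounds.

Measured so far:
- compound 1 `O=C(/C=C/c1ccc2c(c1)B(O)OC2)c1ccc(C(F)(F)F)cc1`, in an ADME assay on L929 cells (Mus musculus) for cytotoxicity, read by resazurin assay, with a stated time of 72 h; on this read-out higher numbers stand for weaker inhibition and lower numbers for stronger inhibition: > 10 ug/mL, a limit of the assay rather than a number.
- compound 2 `COCOc1ccccc1C(=O)/C=C/c1ccc2c(c1)B(O)OC2`, in this assay: 9.02 ug/mL.

Compound 1 stands at the limit of > 10 ug/mL in this assay, at which 1 of the 2 values shown sits; no number is available for it. Compound 2 gives a number close to that limit. Compound 3 `CCOC(=O)c1ccc(C(=O)/C=C/c2ccc3c(c2)B(O)OC3)cc1` differs from compound 1 by ethoxycarbonyl in place of trifluoromethyl on an aromatic carbon. Going by the values given here, no step between measured compounds is available, so nothing measured bears directly on this change. In this assay the step of a number no higher from compound 1 to compound 3 (the limit leaves the size open) is expected to be none beyond the scatter. For compound 3 the estimate is 10 ug/mL, with a range from 5 ug/mL to 20 ug/mL.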

Compound 3, half-maximal inhibitory concentration: > 10 ug/mL
Compound 3 was reported as a limit; the forecaster's own chance of this, stated with the estimate: 50%; the middle value lies on the limit itself.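

Going by these compounds alone, compound 1 and compound 3 are both reported only as a limit of the assay in this assay, so no step between them can be read: the limit of > 10 ug/mL in this assay, at which 2 of the 3 values shown sit. The compounds shown leave open whether ethoxycarbonyl in place of trifluoromethyl shifts the value at all.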